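A few compounds are considered here, and "the series" means these few. Any claim that something is new, unique, unknown or untested is made for them only; others in the source may bear on it.

Compound 1, `Cc1cccc(S(=O)(=O)c2ccc(CNC(=O)c3cc4cnccc4[nH]3)cc2)c1`, was tested in an ADME assay on microsomes from liver (Homo sapiens) for metabolic stability, read by LC-MS, with a stated time of 30 min, tested at 1 uM (on this read-out lower numbers stand for a less stable compound and higher numbers for a more stable compound), where compound 1 gives 49%. Among the three compounds measured so far it holds the second highest number. Compound 3, `O=C(NCc1ccc(S(=O)(=O)c2ccccc2)cc1)c1cnc2nccn2c1`, holds the higher number and gives 60%, a gap beyond the usual scatter, while compound 2, `CC(NC(=O)c1cc2cnccc2[nH]1)c1ccc(S(=O)(=O)N2CCCCC2)cc1`, holds the lower number and gives 34%, also beyond the scatter.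

The next compound is compound 4, `O=C(NCc1ccc(S(=O)(=O)c2ccc(F)cc2)cc1)c1cc2cnccc2[nH]1`. Compared with compound 1 it carries 4-fluorophenyl in place of 3-methylphenyl on a sulfonyl sulfur. For the measured compounds named here, no measured pair shows a change of this kind, so the step cannot be read from the numbers at hand. Compound 4 is expected to land close to its parent, with an estimated 53% and a range from 38% to 68%. The expected step of a number 4 percentage points higher from compound 1 to compound 4 (within the scatter) is estimated to stay within the scatter.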

Compound 4, percent of the compound remaining: 91%
Compound 4: middle estimate off by 38 percentage points, on the low side; measured number outside the range, above it.
By their numbers in this assay, from the lowest: compound 2; then compound 1; then compound 3; then compound 4.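

In this assay the exchange of 3-methylphenyl for 4-fluorophenyl on a sulfonyl sulfur gives a number 42 percentage points higher from compound 1 to compound 4 (beyond the scatter) and shows that this position can strongly move the read-out. The two groups have the same count of heavy atoms and the same kind of ring, so even a swap this small in those counts can matter here. For the compounds shown here, nothing measured so far explains the rise.

Going by these compounds, whether the step comes from gaining the fluorine or from losing the methyl stays open, as both changes arrive together. On these data alone, how a chlorine atom or a methoxy group on that ring would behave on the same core is also open.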